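Swapping a hexyl chain for a cyclopentyl ring

The source may report more compounds than this note shows. Statements on the series, on what has been measured and on what is new or still open speak of the compounds shown alone.

Among the compounds with values here, compound 2 `CCCCCCCc1nc(N)n(CC(=O)Nc2ccccc2)c1-c1ccccc1Br` is one of two compounds measured in a functional assay on A-375 cells (Homo sapiens) for antiproliferative activity, read by MTT assay, with a stated time of 48 h (a higher number here means a weaker inhibitor, a lower number a stronger inhibitor), where compound 2 gives 9200 nM. Compound 1 `CCCCCCc1nc(N)n(CC(=O)Nc2ccccc2)c1-c1ccccc1Br` gives 5700 nM, and a 1.6-fold higher number from compound 1 to compound 2 (0.21 log units; within the scatter). Compound 3 `Nc1nc(CC2CCCC2)c(-c2ccccc2Br)n1CC(=O)Nc1ccccc1` differs from compound 2 by cyclopentyl in place of hexyl on a saturated chain carbon bound to an aromatic carbon. Within the data shown here, the only step measured, from compound 1 to compound 2, changed the chain length and stayed within the scatter, but no step replaces a chain by a ring, so little can be inferred. The expected change is a 1.3-fold lower number from compound 2 to compound 3 (0.12 log units; within the scatter), with compound 3 estimated at 7000 nM in this assay, between 2500 nM and 20000 nM.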

Compound 3, half-maximal inhibitory concentration: 24300 nM
Beside the measured number, compound 3's estimate is 3.5-fold (0.54 log units) below it, and the stated range ends below it.
By their numbers in this assay, from the lowest: compounds 1 and 2 (each within the scatter of the next); then compound 3.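

In this assay cyclopentyl in place of hexyl gives a 2.6-fold higher number from compound 2 to compound 3 (0.42 log units; beyond the scatter) and cyclopentyl in place of pentyl gives a 4.3-fold higher number from compound 1 to compound 3 (0.63 log units; beyond the scatter) at this position, on a saturated chain carbon bound to an aromatic carbon. Both steps lie beyond the scatter, so this position does respond to a change in the group it carries, and here the ring gives the weaker inhibitor. Nothing available explains this difference.

The compounds shown leave open whether a cyclopropyl ring or a branched chain such as isobutyl would also weaken inhibition here. From the compounds shown here alone, how a chain ending in an amine would compare also remains open.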